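Replacing the carbamate cap of compound 1 with an oxadiazole

The source may hold more compounds than are shown below. What is called first, only, known or untested is meant among the compounds shown, and "the series" means these compounds.

Compound 1 `CC(C)(C)OC(=O)N1CCC(Oc2ncnc3c2CCN3c2ccc(S(C)(=O)=O)cc2F)CC1` is one of three analogues sharing a core and differing only in the group carried on an amine nitrogen in a ring. In a functional assay on CHO-K1 cells with Glucose-dependent insulinotropic receptor (Homo sapiens) as the target, read by a luciferase reporter, with a stated time of 5 h (a higher number here means a larger maximal response, a lower number a smaller maximal response), compound 1 gives 139%, the highest of the three numbers. Compound 2 `CC(C)COC(=O)N1CCC(Oc2ncnc3c2CCN3c2ccc(S(C)(=O)=O)cc2F)CC1` gives 94% and compound 3 `CS(=O)(=O)c1ccc(N2CCc3c(OC4CCN(C(=O)OCCF)CC4)ncnc32)c(F)c1` gives 86%. Both changes to the cap of compound 1 lowered the response well beyond the scatter: a number 45 percentage points lower from compound 1 to compound 2 (beyond the scatter), and a number 53 percentage points lower from compound 1 to compound 3 (beyond the scatter). Between the two smaller caps there was little to separate them, since a number 8 percentage points lower from compound 2 to compound 3 (within the scatter).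

Compound 4 `CC(C)c1noc(N2CCC(Oc3ncnc4c3CCN4c3ccc(S(C)(=O)=O)cc3F)CC2)n1` takes a larger step from compound 1: 3-isopropyl-1,2,4-oxadiazol-5-yl in place of tert-butoxycarbonyl on an amine nitrogen in a ring. For the measured compounds named here, no measured pair replaces a tert-butoxycarbonyl with a ring of this kind, so the two carbamate steps are the only guide. They show that any departure from tert-butyl at this position cut the maximal response by a large amount, and a change that removes the carbonyl altogether and brings in a five-membered aromatic ring with three hetero atoms is expected to do at least as much. The estimate for compound 4 is therefore a large drop, a number 49 percentage points lower from compound 1 to compound 4 (beyond the scatter), with wide uncertainty because only a number 45 percentage points lower from compound 1 to compound 2 (beyond the scatter) and a number 53 percentage points lower from compound 1 to compound 3 (beyond the scatter) inform it. Compound 4 is expected to reach about 90%, somewhere between 55% and 130%.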

Compound 4, largest response reached (reported as percent of maximum), in percent of the reference or control that the assay uses: 124%
For compound 4 the middle estimate is 34 percentage points below the measured one; measured number inside the range.
By their numbers in this assay, from the lowest: compounds 3 and 2 (each within the scatter of the next); then compound 4; then compound 1.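

The oxadiazole shows that the carbonyl of the carbamate is not required for a high maximal response at this ring nitrogen: in this assay, the change that removes it gives only a number 15 percentage points lower from compound 1 to compound 4 (beyond the scatter), a smaller loss than either carbamate change produced. The earlier rule, that any departure from tert-butoxycarbonyl costs a large part of the response, therefore holds only among the three carbamates, although compound 1 still gives the highest number of the four. The ring also clearly outperforms the other two carbamates, with a number 30 percentage points higher from compound 2 to compound 4 (beyond the scatter) and a number 38 percentage points higher from compound 3 to compound 4 (beyond the scatter), so a carbamate cap is no advantage in itself, and what matters seems to be which cap is used. Nothing in the material shown explains why this ring retains so much of the response.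

With a single oxadiazole in the set, the contribution of its isopropyl group cannot be separated from that of the ring itself, so a tert-butyl or a cyclopropyl on the same ring remains an open comparison. A urea or a simple amide on this nitrogen is also untested here, which leaves open how other groups carrying a carbonyl would compare with the carbamates and the oxadiazole.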